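The source may report more compounds than this note shows. Statements on the series, on what has been measured and on what is new or still open speak of the compounds shown alone.

Measured compounds:
Compound 1, `O=C(NNC(=O)c1ccccc1[N+](=O)[O-])c1ccc(-n2cccc2)cc1`: 182000 nM
Compound 2, `O=C(NNC(=O)c1ccccc1Br)c1ccc(-n2cccc2)cc1`: 198000 nM
Compound 3, `Brc1ccc(-c2nnc(-c3ccc(-n4cccc4)cc3)o2)cc1`: 260000 nM

Three compounds sharing a pyrrolyl-phenyl fragment were tested in an ADME assay on Vero cells (Chlorocebus sabaeus) for cytotoxicity, read by MTT assay, with a stated time of 72 h; a higher number here means a weaker inhibitor, a lower number a stronger inhibitor. Compound 1 gives 182000 nM. Compound 2 gives 198000 nM. Compound 3 gives 260000 nM; its number is within the scatter of both other compounds, so no order among the three can be claimed.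

Compound 2 and compound 1 differ in one place, (nitro in place of bromo on an aromatic carbon). The step in this assay is a 1.1-fold lower number from compound 2 to compound 1 (0.04 log units; within the scatter). Compound 3 carries a different core from compound 2; the difference between the two cores is not broken down here, and the two values show no gap beyond the scatter.

Compound 4, `O=[N+]([O-])c1ccc(-c2nnc(-c3ccc(-n4cccc4)cc3)o2)cc1`, is not yet measured. It differs from compound 3 by nitro in place of bromo on an aromatic carbon. This is the same kind of change as that from compound 2 to compound 1, but the place is not identical: in the earlier pair the group sits ortho to a large group, whereas in compound 4 it sits para to a large group.

The expectation for compound 4 rests on the earlier pair, where the step of a 1.1-fold lower number from compound 2 to compound 1 (0.04 log units; within the scatter) stayed within the scatter. The step of a 1.1-fold lower number from compound 3 to compound 4 (0.03 log units; within the scatter) is therefore expected to be small as well. Compound 4 is estimated at 240000 nM in this assay, with a range from 120000 nM to 480000 nM.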

Compound 4, half-maximal inhibitory concentration: 258000 nM
Compound 4: the middle estimate sits 1.1-fold (0.03 log units) below what was measured; the range from low to high includes it.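

In this assay, nitro in place of bromo on an aromatic carbon, para to a large group, gives a 1.0-fold lower number from compound 3 to compound 4 (0.00 log units; within the scatter), and this step does not differ from the one seen earlier on the other core: the same change on two cores in this assay, a 1.1-fold lower number (0.04 log units; within the scatter) from compound 2 to compound 1 and a 1.0-fold lower number (0.00 log units; within the scatter) from compound 3 to compound 4, 1.1-fold (0.03 log units) apart, within the scatter of two such steps. The change therefore carried from the core of compound 1 to the core of compound 3 with the same outcome, in that neither pair shows a step beyond the scatter and the two steps agree within their own scatter. This does not show that the change would remain without consequence on any further core or in any other assay, and it cannot separate core from place, since the group sits para to a large group in compound 4 but elsewhere in compound 1, and two pairs are too few to support a general rule.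

The compounds shown leave open whether an amine, a carboxylic acid or a methoxy group in the same place would also stay within the scatter of the bromo compounds. They also leave open whether any change to the shared pyrrolyl-phenyl fragment itself would move the number in this assay beyond the scatter.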